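Cytotoxicity notes on a nucleoside series, compound 3 to 4

The source may report more compounds than this note shows. Statements on the series, on what has been measured and on what is new or still open speak of the compounds shown alone.

Measured so far:
compound 1 `CC(=O)OC[C@H]1O[C@@H](n2cc(-c3cn(Cc4ccccc4)nn3)c(=O)[nH]c2=O)C[C@@H]1OC(C)=O` — 92.3%
compound 2 `CCCCCCCCc1cc(-c2cn([C@H]3C[C@H](O)[C@@H](CO)O3)c(=O)[nH]c2=O)on1` — 88.2%
compound 3 `CCCc1cc(-c2cn([C@H]3C[C@H](OC(C)=O)[C@@H](COC(C)=O)O3)c(=O)[nH]c2=O)on1` — 98.8%

In a functional assay on HCT-15 cells (Homo sapiens) for cytotoxicity, read by sulforhodamine B assay, tested at 10 uM (a higher number here means more inhibition at the concentration tested (going by the name of the read-out), a lower number less inhibition), compound 3 gives 98.8%, the highest of the three numbers. Compound 1 gives 92.3%, which lies within the scatter of compound 3, so no order between these two can be read. Compound 2 gives 88.2%, beyond the scatter below compound 3.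

Compound 4 `CC(=O)OC[C@H]1O[C@@H](n2cc(-c3cc(-c4ccc(C(C)C)cc4)no3)c(=O)[nH]c2=O)C[C@@H]1OC(C)=O` differs from compound 3 in one place: 4-isopropylphenyl in place of propyl on an aromatic carbon. Within the data shown here, no step between two measured compounds touches this position, so the data give no direct measure of what such a change does in this assay. The three measured compounds carry quite different groups at this position and all sit high, which argues against a large move in either direction. For compound 4 the step expected from compound 3 is a number 6.8 percentage points lower from compound 3 to compound 4 (within the scatter), no more than the scatter. Compound 4 is therefore expected to give about 92%, with a range from 75% to 100%.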

Compound 4, a percentage reported as inhibition, at one concentration (the size of the read-out at that concentration, not a potency): 80.9%
Compound 4: the middle estimate sits 11.1 percentage points above what was measured, within the range that was stated.
By their numbers in this assay, from the lowest: compounds 4, 2, 1 and 3 (each within the scatter of the next, the first and the last beyond it).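

In this assay, among these compounds, the change to 4-isopropylphenyl in place of propyl on an aromatic carbon gives a number 17.9 percentage points lower from compound 3 to compound 4 (beyond the scatter), the first measured step at this position. The position is therefore not indifferent to the group it carries, although compound 4 still gives 80.9% at the concentration tested. Nothing measured here accounts for the step.

The compounds shown leave open whether the step follows the six-membered aromatic ring itself or the isopropyl group on it, and an unsubstituted phenyl at the same carbon would separate the two. Also open, as far as these compounds go, is how this position responds to a group of another kind, such as a propyl chain ending in an amine or a carboxylic acid.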